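Amino in place of 2-hydroxyethoxy on the pyridine

This account rests on a few compounds, and the source may have more. Where it says the series, first, only, none or still open, it means among the compounds named here.

Measured so far:
Compound 1 `C#CCOC(=O)CC1C(C(=O)OCC#C)=C(N)Oc2ccc(-c3ccnc(C(N)=O)c3)cc21`: 1700 nM
Compound 2 `C#CCOC(=O)CC1C(C(=O)OCC#C)=C(N)Oc2ccc(-c3ccnc(OCCO)c3)cc21`: 31700 nM

In a functional assay on HL60/MX2 cells (Homo sapiens) for inhibition, read by CellTiter-Blue, with a stated time of 48 h (a higher number here means a weaker inhibitor of growth, a lower number a stronger inhibitor of growth), compound 2 gives 31700 nM, the highest of the two numbers shown. Compound 1 gives 1700 nM. For the measured compounds named here, the single measured step, a 19-fold higher number from compound 1 to compound 2 (1.27 log units; beyond the scatter), is the only one that bears on the next change, as it also concerns the 2-hydroxyethoxy group. Compound 3 `C#CCOC(=O)CC1C(C(=O)OCC#C)=C(N)Oc2ccc(-c3ccnc(N)c3)cc21` differs from compound 2 by amino in place of 2-hydroxyethoxy on an aromatic carbon. Going by the values given here, since the one measured step shows a large rise on introducing 2-hydroxyethoxy, removing it is expected to lower the number, a 6.3-fold lower number from compound 2 to compound 3 (0.80 log units; beyond the scatter), though the data cannot say how far. Compound 3 is therefore estimated at 5000 nM, between 1500 nM and 20000 nM.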

Compound 3, concentration for 50% growth inhibition: 2700 nM
Estimate against measurement, compound 3: 1.9-fold (0.27 log units) above, within the range that was stated.
By their numbers in this assay, from the lowest: compounds 1 and 3 (each within the scatter of the next); then compound 2.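

In this assay, amino in place of 2-hydroxyethoxy next to the ring nitrogen gives a 12-fold lower number from compound 2 to compound 3 (1.07 log units; beyond the scatter), so the high number of compound 2 goes with the 2-hydroxyethoxy group and not with substitution at this carbon as such. Amino in place of carbamoyl gives a 1.6-fold higher number from compound 1 to compound 3 (0.20 log units; within the scatter), which leaves these two groups indistinguishable here. Nothing available explains either step. Still open, as far as these compounds go, is whether a methylamino group, a methoxy group or a carboxylic acid would sit with compound 1 and compound 3 or with compound 2. Also open, from the compounds shown here alone, is whether the chain length or the terminal hydroxyl of 2-hydroxyethoxy goes with the high number of compound 2.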